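Replacing the 4-methoxyphenyl group of compound 2

The compounds below may be only part of what the source reports. "The series", "measured", "known", "first", "only" and "open" are said of these compounds alone.

Compound 1 `Cc1ccc2nc(NC(=O)/C=C/OC3=CC=C3)sc2c1` gives 505 umol/kg
Compound 2 `COc1ccc(/C=C/C(=O)Nc2nc3ccc([N+](=O)[O-])cc3s2)cc1` gives 315 umol/kg
Compound 3 `COc1ccc(C2CC(Nc3nc4ccc(C)cc4s3)=NN2C(C)=O)cc1` gives 37.3 umol/kg

In a functional assay on the whole organism (Hindlimb, strain albino) with Mus musculus as the target, in the maximal electroshock model, with a stated time of 0.5 h (a lower number here means that less compound is needed, a higher number that more compound is needed for the effect), compound 2 sits within the usual scatter of compound 1 and clearly higher than compound 3.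

Compound 4 `O=C(/C=C/OC1=CC=C1)Nc1nc2ccc([N+](=O)[O-])cc2s1` has not been measured yet. Among the compounds with values here, the change from compound 2 is a group of 5 heavy atoms (4 carbon, 1 oxygen; one four-membered non-aromatic ring of carbon only) in place of a group of 8 heavy atoms (7 carbon, 1 oxygen; one six-membered aromatic ring of carbon only), on a double-bonded chain carbon bound to a double-bonded chain carbon and no measured pair shows this change alone. The entering group also stands in compound 1 at 505 umol/kg and that value lies within the scatter of compound 2, so little change is expected. The expected step is a 1.3-fold higher number from compound 2 to compound 4 (0.10 log units; within the scatter) and this is a small rise within the scatter. For compound 4 the estimated value is 400 umol/kg with an expected range from 160 umol/kg to 900 umol/kg in this test.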

Compound 4, dose for half-maximal effect: 597 umol/kg
Estimate against measurement, compound 4: 1.5-fold (0.17 log units) below; the range from low to high includes it.
By their numbers in this assay, from the lowest: compound 3; then compounds 2, 1 and 4 (each within the scatter of the next).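

In this assay, within the data shown here, the group with the four-membered ring in place of 4-methoxyphenyl on the double-bonded chain carbon gives a step within the scatter (a 1.9-fold higher number from compound 2 to compound 4 (0.28 log units; within the scatter)), the first direct comparison of these two groups at this place. With that four-membered ring group held fixed, nitro in place of methyl on an aromatic carbon also stays within the scatter (a 1.2-fold higher number from compound 1 to compound 4 (0.07 log units; within the scatter)). No measurement shown offers an explanation for either step. As far as these compounds go, whether an amine or a carboxylic acid on this chain carbon would stay within the scatter remains open. So does the effect of chlorine in place of nitro on that aromatic carbon.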